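The compounds below may be only part of what the source reports. "The series", "measured", "known", "first", "only" and "open" are said of these compounds alone.

Three sulfonate esters have been tested in a functional assay on HT-29 cells (Homo sapiens) for antiproliferative activity, read by sulforhodamine B assay, with a stated time of 48 h; a lower number here means a stronger inhibitor, a higher number a weaker inhibitor. Compound 1, `CC(C)C(=O)Nc1cccc(S(=O)(=O)Oc2ccccc2C(C)C)c1`, gives 16000 nM. Compound 2, `CC(C)c1ccccc1OS(=O)(=O)c1cccc(NC(=O)C(C)(C)C)c1`, gives 19000 nM. The only difference between these two is methyl in place of hydrogen on a saturated chain carbon bound to a carbonyl carbon and two saturated chain carbons, and that change made a step of a 1.2-fold higher number from compound 1 to compound 2 (0.07 log units; within the scatter). Compound 3, `CC(=O)Nc1ccc(S(=O)(=O)Oc2ccccc2C(C)C)cc1`, carries a different core; the difference between the core of compound 1 and the core of compound 3 is not broken down here. In this assay compound 3 gives 23000 nM, and its value and those of compound 1 and compound 2 all lie within the usual scatter of one another, so none of the three can be singled out as stronger or weaker.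

Compound 4, `CCC(=O)Nc1ccc(S(=O)(=O)Oc2ccccc2C(C)C)cc1`, has not yet been measured. It differs from compound 3 by methyl in place of hydrogen on a saturated chain carbon bound to a carbonyl carbon. Going by the values given here, this is the same kind of change as the one from compound 1 to compound 2, though the place is not identical: in the earlier pair the saturated chain carbon is bound to a carbonyl carbon and two saturated chain carbons, whereas in compound 3 it is bound to a carbonyl carbon only. Because the earlier step was a 1.2-fold higher number from compound 1 to compound 2 (0.07 log units; within the scatter), the step from compound 3 to compound 4 is expected to be small as well, estimated at a 1.0-fold higher number from compound 3 to compound 4 (0.02 log units; within the scatter). On that basis compound 4 is expected to give about 24000 nM in this assay, with a plausible range from 11000 nM to 52000 nM.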

Compound 4, half-maximal inhibitory concentration: 7400 nM
Estimate against measurement, compound 4: 3.2-fold (0.51 log units) above; the whole stated range lies above it.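

In this assay, adding a methyl on the saturated chain carbon bound to a carbonyl carbon, which turns acetyl into propanoyl, gave a 3.1-fold lower number from compound 3 to compound 4 (0.49 log units; beyond the scatter). Going by these compounds alone, the same kind of change therefore did not behave alike on the two cores, and the size of the step seen on one core cannot simply be carried over to the other: the same change on two cores in this assay, a 1.2-fold higher number (0.07 log units; within the scatter) from compound 1 to compound 2 and a 3.1-fold lower number (0.49 log units; beyond the scatter) from compound 3 to compound 4, 3.7-fold (0.57 log units) apart, beyond the scatter of two such steps This does not explain why the steps differ, and it does not give a rule for the series: each core offers only one pair, and the two changes are not at identical places, as the carbon in the earlier pair is also bound to two saturated chain carbons.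

Still open, as far as these compounds go, is whether a longer chain on the core of compound 3, such as butanoyl, would lower the number further or raise it again, and what an amine at the end of that chain would do. Also open, from the compounds shown here alone, is how acetyl and propanoyl would compare on the core of compound 1, which would test the identical place on both cores.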